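The compounds below may be only part of what the source reports. "The series", "measured", "known", "first", "only" and "open" are said of these compounds alone.

Measured so far in a physicochemical assay for lipophilicity, read by HPLC, measured as chromatographic lipophilicity; on this read-out higher numbers stand for higher lipophilicity and lower numbers for lower lipophilicity:
- Compound 1 `CCC/N=C1\S/C(=C\c2ccc(C(=O)OC)c(Cl)c2)C(=O)N1c1ccccc1C`: > 4.4
- Compound 2 `CCC/N=C1\S/C(=C\c2ccc(C(=O)NCCO)cc2)C(=O)N1c1ccccc1C`: 2.3
- Compound 3 `CCC/N=C1\S/C(=C\c2ccc(C(=O)NCC(=O)N(C)C)cc2)C(=O)N1c1ccccc1O`: 1.9

Compound 3, at 1.9, holds the lower of the two actual numbers, and the gap to compound 2, at 2.3, lies beyond the scatter. Compound 1 gave only a limit, > 4.4, and not a number.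

Compound 4 `CCC/N=C1\S/C(=C\c2ccc(C(=O)OCc3oc(=O)oc3C)cc2)C(=O)N1c1ccccc1O` has not yet been measured. It keeps the rest of compound 3 and changes one group: a group of 9 heavy atoms (5 carbon, 4 oxygen; one five-membered aromatic ring with 2 hetero atoms) in place of a group of 7 heavy atoms (4 carbon, 2 nitrogen, 1 oxygen; no ring), on a carbonyl carbon. The amide of compound 3 thus gives way to an ester carrying a five-membered aromatic ring.

Among the compounds with values here, no two measured compounds differ in one place only, so no measured step shows the size of this change directly. Within the data shown here, the closest guide is compound 1, the only measured compound with an ester on such a carbonyl carbon, though it also differs elsewhere; its result is the limit > 4.4. On that slender basis, a rise beyond the scatter is expected in this assay, with wide uncertainty. The expected change is a number 1.60 log units higher from compound 3 to compound 4 (beyond the scatter). The estimate for compound 4 is 3.5, with an expected range from 2.8 to 4.2.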

Compound 4, distribution coefficient: 3.3
The estimate for compound 4 lay 0.20 log units above the measured number, within the range that was stated.
By their numbers in this assay, from the lowest: compound 3; then compound 2; then compound 4. At a limit, above all of these: compound 1.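

Within the data shown here, the swap on the carbonyl carbon, where the ((dimethylcarbamoyl)methyl)amino group leaves and an ester group with a five-membered aromatic ring enters, gives a number 1.40 log units higher from compound 3 to compound 4 (beyond the scatter) in this assay, and this is the first measured step that changes one place only. It shows that this place, on a carbonyl carbon whose other neighbour is an aromatic carbon, can move the read-out well beyond the scatter while the rest of the molecule stays the same. Compound 1 also carries an ester on such a carbonyl carbon, but it differs elsewhere as well and gives a limit rather than a number: the limit of > 4.4 in this assay, at which 1 of the 4 values shown sits.

This single step changes the atoms, the ring and the hydrogen-bond donor and acceptor counts together, so it cannot say how much of the rise belongs to any one of them. A plain ethyl ester without the ring would separate the ester link from the ring, and a carboxylic acid on the same carbonyl carbon would show where the unesterified parent stands in this assay.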